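The source may hold more compounds than are shown below. What is called first, only, known or untested is meant among the compounds shown, and "the series" means these compounds.

Compounds measured so far:

Compound 1 `C[C@H]1N=C2C[C@H]3C[C@H](C3(C)C)[C@@]2(C)OC1=O` — in a functional assay on MCF7 cells (Homo sapiens) for antiproliferative activity, read by sulforhodamine B assay, with a stated time of 48 h (on this read-out higher numbers stand for weaker inhibition and lower numbers for stronger inhibition), compound 1 gives 38000 nM
Compound 2 `CC(C)(C)OC(=O)NCCCC[C@H]1N=C2C[C@H]3C[C@H](C3(C)C)[C@@]2(C)OC1=O` — in this assay compound 2 gives 15300 nM

Going by the values given here, compound 1 stands at the higher of the two numbers so far: in this assay compound 1 gives 38000 nM, while compound 2 gives 15300 nM, a gap that lies beyond the usual scatter of the read-out. Among the compounds with values here, no single-site step between the two measured compounds has been worked out, so their two values are simply what they show.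

The piece follows the step from compound 1 to the unmeasured compound 3 `C[C@@H]1N=C2C[C@@H]3C[C@@H](C3(C)C)[C@]2(C)OC1=O`. The change is the two compounds have the same atoms and bonds and differ only in configuration as drawn: 4 of 4 stereo elements differ (all stereocentres are inverted: mirror images); a stereocentre at a saturated ring carbon is drawn R in compound 1 and S in compound 3; a stereocentre at a saturated ring carbon is drawn R in compound 1 and S in compound 3; a stereocentre at a saturated ring carbon is drawn R in compound 1 and S in compound 3; a stereocentre at a saturated ring carbon is drawn R in compound 1 and S in compound 3; compound 3 is thus the mirror image of compound 1, with nothing leaving and nothing entering. Within the data shown here, the data hold no other pair of mirror images, so there is nothing measured to set the size of such a step against. Among the measured compounds shown here, with compound 1 already at 38000 nM, and no step to guide the direction, the expectation for compound 3 in this assay is a number near that of compound 1, with the step from compound 1 to compound 3 estimated at a 1.1-fold higher number from compound 1 to compound 3 (0.02 log units; within the scatter), in either direction and possibly within the scatter. Compound 3 is therefore estimated at 40000 nM, in a range from 10000 nM to 150000 nM.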

Compound 3, half-maximal inhibitory concentration: 154000 nM
Estimate against measurement, compound 3: 3.9-fold (0.59 log units) below; measured number above the stated range.
By their numbers in this assay, from the lowest: compound 2; then compound 1; then compound 3.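

Inverting every stereocentre of the shared core gives a 4.1-fold higher number from compound 1 to compound 3 (0.61 log units; beyond the scatter) in this assay, which shows that this read-out distinguishes the two mirror-image forms. Compounds 1 and 2 are drawn with the same configuration at the core, so they could not reveal this; among the compounds shown, the configuration of compound 1 is now the one favoured over its mirror image. The gap can be attributed to configuration alone, because nothing else separates the pair: the fact that compounds 1 and 3 differ only in the configuration as drawn.

The compounds shown do not reveal whether one stereocentre carries most of the step or whether it takes the inversion of all of them together, as only the fully inverted form is available for comparison. They also leave open whether the same preference for the configuration of compound 1 would hold on cores bearing a longer chain, a free amine or a carboxylic acid, and whether the step would then grow, shrink or reverse.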